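The compounds below may be only part of what the source reports. "The series", "measured", "known", "first", "only" and "open" are said of these compounds alone.

Measured so far in a functional assay on PC-12 cells (Rattus norvegicus) for cytotoxicity, read by MTT assay, with stated times of 2 h and 24 h, tested at 5 uM; a lower number here means a weaker effect, a higher number a stronger effect of the compound at the concentration tested:
- compound 1, `CCc1ccc(-n2nc(-c3ccc(C(F)(F)F)cc3O)nc2-c2ccccc2O)cc1`: 95.4%
- compound 2, `COc1ccc(-n2nc(-c3ccc(C(F)(F)F)cc3O)nc2-c2ccccc2O)cc1`: 86.6%
- compound 3, `Oc1cc(C(F)(F)F)ccc1-c1nc(-c2ccccc2O)n(-c2ccc(OC(F)(F)F)cc2)n1`: 84.9%

Compound 3 holds the lowest of the three numbers in this assay. Its nearest neighbour is compound 2, with a number 1.7 percentage points lower from compound 2 to compound 3 (within the scatter); the furthest is compound 1, with a number 10.5 percentage points lower from compound 1 to compound 3 (beyond the scatter), the only gap in the set that exceeds the scatter. Between the other two, a number 8.8 percentage points lower from compound 1 to compound 2 (within the scatter).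

Compound 4, `COc1ccccc1-n1nc(-c2ccc(C(F)(F)F)cc2O)nc1-c1ccccc1O`, is the next candidate. It differs from compound 3 by 2-methoxyphenyl in place of 4-(trifluoromethoxy)phenyl on an aromatic nitrogen. All three measured steps replace one group with another on the aryl ring that sits on the same ring nitrogen, and all were small: one modest fall, two within the scatter. Among the measured compounds shown here, no measured step moves a group to a different position of that ring, so the present change is only partly covered. Given that the whole measured span is narrow and that the methoxy-bearing compound 2 gives 86.6%, a small rise is expected for compound 4, namely a number 3.1 percentage points higher from compound 3 to compound 4 (within the scatter). Compound 4 is therefore estimated at 88%, with a range of 78% to 97%.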

Compound 4, a percentage reported as activity, at one concentration (the size of the read-out at that concentration, not a potency): 85.6%
Compound 4: middle estimate off by 2.4 percentage points, on the high side; the range from low to high includes it.
By their numbers in this assay, from the lowest: compounds 3, 4, 2 and 1 (each within the scatter of the next, the first and the last beyond it).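

In this assay, among the compounds shown here, moving the methoxy group on the aryl ring, with 2-methoxyphenyl in place of 4-methoxyphenyl, gives a number 1 percentage points lower from compound 2 to compound 4 (within the scatter) and is the first measured change of position on this ring. The other two exchanges at this aromatic nitrogen give a number 0.7 percentage points higher from compound 3 to compound 4 (within the scatter) and a number 9.8 percentage points lower from compound 1 to compound 4 (within the scatter), so compound 4 cannot be told apart from any of the three earlier compounds, although compound 1 and compound 3 do differ from each other. Nothing available here speaks to a cause of these readings.

Going by these compounds, whether an amine or a carboxylic acid on this aryl ring would keep the reading in the same narrow span remains open. Also open, on these data alone, is whether ethyl or trifluoromethoxy would tolerate the same change of position as methoxy.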